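The source may hold more compounds than are shown below. What is called first, only, known or untested is meant among the compounds shown, and "the series" means these compounds.

Compounds measured so far:
compound 1, `COc1cc(-c2cc(/C=C/C(=O)c3ccc(Cl)c(Cl)c3)[nH]n2)cc(OC)c1OC`, 76%
compound 2, `COc1ccc(C(=O)/C=C/c2cc(-c3cc(OC)c(OC)c(OC)c3)n[nH]2)cc1OC`, 45%

Among the compounds with values here, in a functional assay on MDA-MB-468 cells (Homo sapiens) for cytotoxicity, read by sulforhodamine B assay, with a stated time of 48 h, tested at 1 uM (a lower number here means a stronger effect, a higher number a weaker effect of the compound at the concentration tested), compound 2 gives 45%, the lowest of the two numbers; its only neighbour, compound 1, gives 76%. Within the data shown here, the one recorded step, a number 31 percentage points lower from compound 1 to compound 2 (beyond the scatter), came from putting 3,4-dimethoxyphenyl in place of 3,4-dichlorophenyl on the carbonyl carbon. Compound 3, `COc1cc(C(=O)/C=C/c2cc(-c3cc(OC)c(OC)c(OC)c3)n[nH]2)cc(OC)c1OC`, has not yet been measured in this assay. It differs from compound 2 by methoxy in place of hydrogen on an aromatic carbon: the added methoxy sits on an aromatic carbon of a six-membered aromatic ring of carbon only, ortho to a methoxy group and meta to a methoxy group. Among the measured compounds shown here, no measured step adds or removes a single methoxy. For the measured compounds named here, the step between compound 1 and compound 2 shows only that the ring on the carbonyl carbon influences the read-out; it does not tell whether one more methoxy will move the number further. For compound 3 the expected step is a number 5 percentage points lower from compound 2 to compound 3 (within the scatter), small, within the scatter or only a little beyond. The estimate for compound 3 is 40%, with a range from 20% to 65%.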

Compound 3, a percentage reported as activity, at one concentration (the size of the read-out at that concentration, not a potency): 59%
The estimate for compound 3 lay 19 percentage points below the measured number, within the range that was stated.
By their numbers in this assay, from the lowest: compound 2; then compound 3; then compound 1.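

In this assay, one more methoxy on the ring attached to the carbonyl carbon, placed ortho to a methoxy group and meta to another, gives a number 14 percentage points higher from compound 2 to compound 3 (beyond the scatter), so the effect at this concentration becomes weaker rather than stronger. The earlier step replaced a whole ring substituent pattern, whereas this one isolates a single aromatic position and shows that the read-out responds to a methoxy there, so adding methoxy to this ring does not by itself strengthen the effect. No measurement here accounts for this shift.

A single step at one position cannot separate the effect of this methoxy's presence from that of its place on the ring, and a fluorine, a hydroxyl or an amine on the same carbon could show whether the loss is specific to methoxy or follows any replacement of hydrogen there. Because each number comes from one concentration, the compounds shown also leave open how the full dose response of compound 3 compares with that of compound 2.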